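This account rests on a few compounds, and the source may have more. Where it says the series, first, only, none or still open, it means among the compounds named here.

Measured compounds:
Compound 1 `O=S(=O)(NCCCNCc1ccc(Cl)c(C(F)(F)F)c1)c1cc(C(F)(F)F)cc(C(F)(F)F)c1` gives 11000 nM in a functional assay on HT-29 cells (Homo sapiens) for inhibition, read by MTT assay, with a stated time of 72 h; a higher number here means a weaker inhibitor of growth, a lower number a stronger inhibitor of growth.
Compound 2 `O=S(=O)(NCCCNCc1cccc(Cl)c1)c1cc(C(F)(F)F)cc(C(F)(F)F)c1` gives 14000 nM in this assay.

For the measured compounds named here, compound 2 carries the highest of the two numbers so far, but its only neighbour is compound 1, and that step, a 1.3-fold higher number from compound 1 to compound 2 (0.10 log units; within the scatter), stays within the scatter, so the two compounds cannot be told apart on these data.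

Compound 3 `COc1cccc(CNCCCNS(=O)(=O)c2cc(C(F)(F)F)cc(C(F)(F)F)c2)c1` differs from compound 2 in one place: methoxy in place of chloro on an aromatic carbon. Going by the values given here, only one measured step exists, a 1.3-fold higher number from compound 1 to compound 2 (0.10 log units; within the scatter), and it changed the same 3-chlorobenzyl group in another way while staying within the scatter; no measured step exchanges a chloro for a methoxy. With nothing pointing in either direction, the expected step from compound 2 is none beyond the scatter, no change at the digits printed from compound 2 to compound 3 (within the scatter). Compound 3 is therefore estimated at 14000 nM in this assay, expected to fall between 5000 nM and 40000 nM.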

Compound 3, concentration for 50% growth inhibition: 10000 nM
Compound 3: middle estimate off by 1.4-fold (0.15 log units), on the high side; low and high end bracket the measured number.
By their numbers in this assay, from the lowest: compounds 3, 1 and 2 (each within the scatter of the next).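

Replacing chloro with methoxy on this aromatic carbon gives a 1.4-fold lower number from compound 2 to compound 3 (0.15 log units; within the scatter) in this assay, so a hydrogen-bond acceptor can enter here, where chloro has none, with no readable change in the number. The other new comparison, which swaps the whole substituted phenyl group, gives a 1.1-fold lower number from compound 1 to compound 3 (0.04 log units; within the scatter) and also shows no readable change. Chlorine on this ring is therefore not needed for activity of this size, and compounds 1, 2 and 3 cannot be told apart, while no evidence is at hand that bears on this result.

As far as these compounds go, it remains open whether a group of another kind at this position, such as an amine or a carboxylic acid, would move the number beyond the scatter. From the compounds shown here alone, a longer chain in the shared core is equally open.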